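A few compounds are considered here, and "the series" means these few. Any claim that something is new, unique, unknown or untested is made for them only; others in the source may bear on it.

Measured compounds:
- compound 1 `CN(C)c1ccc(C2CC(c3ccc(-n4ccnc4)cc3)=NN2)cc1`: in a functional assay on MDA-MB-231 cells (Homo sapiens) for inhibition, read by sulforhodamine B assay, tested at 10 uM (a lower number here means less inhibition, a higher number more inhibition at the concentration tested (going by the name of the read-out)), compound 1 gives 7.6%
- compound 2 `CC(=O)N1N=C(c2ccc(-n3cncn3)cc2)CC1c1ccc(N(C)C)cc1`: in this assay compound 2 gives 7.4%

Compound 2 holds the lowest of the two numbers in this assay; compound 1 sits a shade higher, a gap within the scatter. Compound 3 `CC(=O)N1N=C(c2ccc(-n3ccnc3)cc2)CC1c1ccc(N(C)C)cc1` differs from compound 2 by a single change: 1H-imidazol-1-yl in place of 1H-1,2,4-triazol-1-yl on an aromatic carbon. Among the measured compounds shown here, no measured pair isolates this change; compound 1 carries the same entering ring but differs from compound 2 elsewhere as well. With both measured values near the floor, the step from compound 2 to compound 3 is expected to stay within the scatter, a number 0.6 percentage points higher from compound 2 to compound 3 (within the scatter). Compound 3 is estimated at 8% in this assay, between 0% and 20%.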

Compound 3, a percentage reported as inhibition, at one concentration (the size of the read-out at that concentration, not a potency): 5%
Beside the measured number, compound 3's estimate is 3 percentage points above it; low and high end bracket the measured number.
By their numbers in this assay, from the lowest: compounds 3, 2 and 1 (each within the scatter of the next).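

In this assay, 1H-imidazol-1-yl in place of 1H-1,2,4-triazol-1-yl on the aromatic carbon para to a large group gives a number 2.4 percentage points lower from compound 2 to compound 3 (within the scatter), so this position now has a matched pair and the exchange of these two rings has no readable effect. Acetyl in place of hydrogen on the ring amine nitrogen gives a number 2.6 percentage points lower from compound 1 to compound 3 (within the scatter), likewise no readable effect. Nothing available explains either step. Still open, on these data alone, is whether a carboxylic acid or a primary amine at this position would give a number beyond the scatter. Also open, as far as these compounds go, is whether a longer acyl chain in place of acetyl would do so.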